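The source may hold more compounds than are shown below. What is called first, only, known or untested is meant among the compounds shown, and "the series" means these compounds.

Measured so far:
Compound 1, `Cc1cc(NC(=O)Cn2nnc(-c3ccc(F)cc3)n2)n(C2CCCCC2)n1`; in an assay on HEK293 cells for activation of Kir3.1/Kir3.2 (Homo sapiens), read by thallium flux (on this read-out lower numbers stand for smaller maximal responses and higher numbers for larger maximal responses), compound 1 gives 92%.
Compound 2, `Cc1cc(NC(=O)Cn2nnc(-c3ccc(F)c(F)c3)n2)n(C2CCCCC2)n1`; in this assay compound 2 gives 93%.
Compound 3, `Cc1cc(NC(=O)Cn2nnc(C3CC3)n2)n(C2CCCCC2)n1`; in this assay compound 3 gives > 68%, which is a limit of the assay and not a number.

Going by these compounds, compound 3 thus stands at a limit only, as noted in the limit of > 68% in this assay, at which 1 of the 3 values shown sits, so its exact position among the three is unknown. The step to compound 4, `Cc1cc(NC(=O)Cn2nnc(-c3cccc(C(F)(F)F)c3)n2)n(C2CCCCC2)n1`, is 3-(trifluoromethyl)phenyl in place of cyclopropyl on an aromatic carbon. Among the measured compounds shown here, two measured steps touch this position: a step that the limit leaves unreadable from compound 1 to compound 3 and a step that the limit leaves unreadable from compound 2 to compound 3, and neither has a readable size. For the measured compounds named here, the only step with a readable size, a number 1 percentage points higher from compound 1 to compound 2 (within the scatter), concerns a different change and stays within the scatter. What remains is that the two compounds bearing an aryl group at this position, compound 1 with 92% and compound 2 with 93%, both reached high values, and compound 4 bears an aryl group there too. Compound 4 is therefore expected to reach 90% in this assay, between 75% and 100%. The step that the limit leaves unreadable from compound 3 to compound 4 is expected to be small or upward, not readable against the limit of compound 3.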

Compound 4, largest response reached (Emax), in percent of the reference or control that the assay uses: 86%
Beside the measured number, compound 4's estimate is 4 percentage points above it; measured number inside the range.
By their numbers in this assay, from the lowest: compounds 4, 1 and 2 (each within the scatter of the next).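

Exchanging 4-fluorophenyl for 3-(trifluoromethyl)phenyl gives a number 6 percentage points lower from compound 1 to compound 4 (within the scatter), and exchanging 3,4-difluorophenyl for it gives a number 7 percentage points lower from compound 2 to compound 4 (within the scatter). In this assay, among the compounds shown here, a phenyl group bearing trifluoromethyl at this position on the five-membered ring therefore cannot be told apart from the two fluorinated phenyl groups, which the earlier compounds could not show. Compound 3 has only a limit, and the steps that touch it cannot be read: the limit of > 68% in this assay, at which 1 of the 4 values shown sits.

Going by these compounds, whether any aryl group at this position differs from cyclopropyl therefore stays open. Also open, on these data alone, is whether the response would hold with an amine or a carboxylic acid on the phenyl ring, or with a longer alkyl chain in its place.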